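Sulfonamide Nitrogen Substituent Change in a Prostaglandin D2 Receptor Series

This account rests on a few compounds, and the source may have more. Where it says the series, first, only, none or still open, it means among the compounds named here.

Measured compounds:
Compound 1 `CCCS(=O)(=O)c1cccc(C#Cc2cc(Cl)ccc2OCC(=O)O)c1`: 9 nM
Compound 2 `CN(c1cccc(C#Cc2cc(Cl)ccc2OCC(=O)O)c1)S(C)(=O)=O`: 122 nM
Compound 3 `Cc1ccc(S(=O)(=O)N(C)C(C)C)cc1C#Cc1cc(Cl)ccc1OCC(=O)O`: 3.8 nM

All three were tested in an assay on CHO cells for displacement of a labelled ligand from prostaglandin D2 receptor 2 (Homo sapiens), read by scintillation counting; on this read-out higher numbers stand for weaker inhibition and lower numbers for stronger inhibition. Compound 3 gives the lowest number of the three, and its separation from compound 1 and from compound 2 lies beyond the scatter in both cases, so compound 3 is the strongest binder shown. Within the data shown here, compound 2 stands far above the others; the single step, a 14-fold higher number from compound 1 to compound 2 (1.13 log units; beyond the scatter), shows how strongly the group on the aromatic carbon can shift the result.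

Compound 4 `Cc1ccc(S(=O)(=O)N(C)CCN(C)C)cc1C#Cc1cc(Cl)ccc1OCC(=O)O` has not yet been measured. It differs from compound 3 in one place: 2-(dimethylamino)ethyl in place of isopropyl on a sulfonamide nitrogen. Among the measured compounds shown here, no measured pair varies the substituent on the sulfonamide nitrogen, so the only step on record, a 14-fold higher number from compound 1 to compound 2 (1.13 log units; beyond the scatter), concerns a different position and bears on the new change only indirectly. Compound 4 is therefore expected to remain near compound 3, with at most a modest shift, a 1.6-fold higher number from compound 3 to compound 4 (0.20 log units; within the scatter). The estimate for compound 4 in this assay is 6 nM, within a range from 2 nM to 20 nM.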

Compound 4, inhibition constant: 369 nM
Compound 4: middle estimate off by 62-fold (1.79 log units), on the low side, and the stated range ends below it.
By their numbers in this assay, from the lowest: compound 3; then compound 1; then compound 2; then compound 4.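

In this assay, among these compounds, replacing isopropyl with 2-(dimethylamino)ethyl on a sulfonamide nitrogen gives a 97-fold higher number from compound 3 to compound 4 (1.99 log units; beyond the scatter), which shows for the first time that the result is highly sensitive to the substituent at this nitrogen. The entering group has 5 heavy atoms, one of them nitrogen, against 3 carbon atoms in the group that leaves, so size and the added nitrogen change together and this single pair cannot separate them. Nothing available explains the loss of binding.

From the compounds shown here alone, it remains open whether the higher number follows the dimethylamino nitrogen or the chain itself, a question that a butyl chain or a 2-methoxyethyl group on the same sulfonamide nitrogen could address. Also open, going by these compounds, is how a carboxylic acid at the end of such a chain would read in this assay.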